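Amino for fluoro on the N-aryl ring of the series

The source may hold more compounds than are shown below. What is called first, only, known or untested is meant among the compounds shown, and "the series" means these compounds.

Measured so far:
compound 1, `COc1cc(C(=O)c2cn(-c3ccccc3)cc2-c2ccc(F)cc2)cc(OC)c1OC`, 78 nM
compound 2, `COc1cc(C(=O)c2cn(-c3ccccc3)cc2-c2ccc(N)cc2)cc(OC)c1OC`, 9 nM
compound 3, `COc1cc(C(=O)c2cn(-c3cccc(F)c3)cc2-c2ccccc2)cc(OC)c1OC`, 350 nM

All three were run in a functional assay on MCF7 cells (Homo sapiens) for inhibition, read by trypan blue exclusion, with a stated time of 3 days; a lower number here means a stronger inhibitor, a higher number a weaker inhibitor. Compound 2 differs from compound 1 by amino in place of fluoro on an aromatic carbon, and the step is an 8.7-fold lower number from compound 1 to compound 2 (0.94 log units; beyond the scatter). Compound 3 and compound 1 are built from the same atoms joined differently; the difference between the two cores is not broken down here. In this assay compound 3 stands with the highest number of the three.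

Compound 4, `COc1cc(C(=O)c2cn(-c3cccc(N)c3)cc2-c2ccccc2)cc(OC)c1OC`, is not yet measured. It differs from compound 3 by amino in place of fluoro on an aromatic carbon. This is the same kind of change as that from compound 1 to compound 2, but at a place that is meta to a large group rather than para to a large group, so the two are not the same.

The expectation rests on the step measured from compound 1 to compound 2, an 8.7-fold lower number from compound 1 to compound 2 (0.94 log units; beyond the scatter); a step of similar kind but somewhat smaller size, a 5.8-fold lower number from compound 3 to compound 4 (0.77 log units; beyond the scatter), is expected for compound 4. Compound 4 is therefore estimated at 60 nM, with the likely range from 20 nM to 200 nM.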

Compound 4, half-maximal inhibitory concentration: 74 nM
Compound 4: middle estimate off by 1.2-fold (0.09 log units), on the low side; the measured number falls inside the stated range.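

In this assay, amino in place of fluoro again lowers the number, with a 4.7-fold lower number from compound 3 to compound 4 (0.67 log units; beyond the scatter), and the steps on the two cores do not separate: the same change on two cores in this assay, an 8.7-fold lower number (0.94 log units; beyond the scatter) from compound 1 to compound 2 and a 4.7-fold lower number (0.67 log units; beyond the scatter) from compound 3 to compound 4, 1.8-fold (0.26 log units) apart, within the scatter of two such steps

The change therefore carries over between these two pairs, even though the amino group is meta to a large group in compound 4 and sits elsewhere in compound 2, so core and place differ together between the pairs. This does not show that the step would hold on a further core, nor does it separate the contribution of the core from that of the place or say which feature of the amino group lies behind the step.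

Still open, as far as these compounds go, is whether a hydroxyl, a methylamino or an acetamido group in the same place would follow amino or fluoro. Also open, from the compounds shown here alone, is how a compound carrying amino at both places would stand in this assay, and whether the two steps would simply add.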